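The source may hold more compounds than are shown below. What is called first, only, known or untested is meant among the compounds shown, and "the series" means these compounds.

Of the compounds shown here, two have numbers so far in a functional assay on DU-145 cells (Homo sapiens) for antiproliferative activity, read by fluorescence and propidium iodide staining, with a stated time of 96 h; on this read-out higher numbers stand for weaker inhibition and lower numbers for stronger inhibition. Compound 1 (`CC(O)(CSc1cc(C(F)(F)F)cc(C(F)(F)F)c1)C(=O)Nc1ccc(C#N)cc1C(F)(F)F`) gives 9090 nM and compound 2 (`CC(O)(CSc1ccccc1C(F)(F)F)C(=O)Nc1cc(C(F)(F)F)cc(C(F)(F)F)c1`) gives 8660 nM. These two values lie within the scatter of each other, so compound 2 stands level with compound 1. Compound 3 (`CC(O)(CSc1ccccc1OC(F)(F)F)C(=O)Nc1cc(C(F)(F)F)cc(C(F)(F)F)c1`) is still unmeasured and differs from compound 2 in a single place: trifluoromethoxy in place of trifluoromethyl on an aromatic carbon. This is trifluoromethoxy in place of trifluoromethyl on an aromatic carbon, ortho to a large group. Among the measured compounds shown here, no measured pair shows this exchange, so the data offer no direct guide to its size. No step beyond the scatter is expected in this assay, and neither direction is favoured. The estimated change, a 1.1-fold lower number from compound 2 to compound 3 (0.03 log units; within the scatter), is therefore small. For compound 3 the expected value is 8000 nM, with an estimated range of 3500 nM to 17000 nM.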

Compound 3, half-maximal inhibitory concentration: 6410 nM
Compound 3: the middle estimate sits 1.2-fold (0.10 log units) above what was measured; measured number inside the range.
By their numbers in this assay, from the lowest: compounds 3, 2 and 1 (each within the scatter of the next).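

In this assay the series now has its first one-place step, on the 2-(trifluoromethyl)phenyl of compound 2: the exchange to 2-(trifluoromethoxy)phenyl gives a 1.4-fold lower number from compound 2 to compound 3 (0.13 log units; within the scatter). At this aromatic carbon, ortho to a large group, trifluoromethoxy and trifluoromethyl therefore stand level, and the added oxygen and hydrogen-bond acceptor bring no step beyond the scatter. No measurement at hand bears on why the two groups read alike here.

Open, going by these compounds, is whether a methoxy group, a chlorine atom or an amine at this place would give a step beyond the scatter, and whether the same exchange reads alike on another carbon of this ring. Compound 1 differs from compound 2 in more than one place, so it offers no reading on either question.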